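The source may hold more compounds than are shown below. What is called first, only, known or untested is meant among the compounds shown, and "the series" means these compounds.

For the measured compounds named here, in a physicochemical assay for solubility (a higher number here means a more soluble compound, a lower number a less soluble compound), compound 1 `O=C(c1ccc(Cl)cc1)N1CCC(NS(=O)(=O)c2cc(S(=O)(=O)c3ccccc3)ccc2C(F)(F)F)CC1` gives 3100 nM, while compound 2 `O=C(C1CCNCC1)N1CCC(NS(=O)(=O)c2cc(S(=O)(=O)c3ccccc3)ccc2C(F)(F)F)CC1` gives 100000 nM, the higher of the two numbers measured so far. Compound 3 `O=C([C@@H]1CCNC1)N1CCC(NS(=O)(=O)c2cc(S(=O)(=O)c3ccccc3)ccc2C(F)(F)F)CC1` departs from compound 2 by one change, pyrrolidin-3-yl in place of piperidin-4-yl on a carbonyl carbon. Going by the values given here, the only measured step, a 32-fold higher number from compound 1 to compound 2 (1.51 log units; beyond the scatter), is large, but it replaced 4-chlorophenyl and bears on this change only indirectly. Among the compounds with values here, no measured pair tests the exchange of a six-membered non-aromatic ring for a five-membered one. The expected result is no shift beyond the scatter, an estimated 1.2-fold lower number from compound 2 to compound 3 (0.07 log units; within the scatter). For compound 3 the estimate is 85000 nM, with an expected range of 40000 nM to 120000 nM.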

Compound 3, solubility: 12500 nM
The estimate for compound 3 lay 6.8-fold (0.83 log units) above the measured number; measured number outside the range, below it.
By their numbers in this assay, from the lowest: compound 1; then compound 3; then compound 2.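

In this assay this position separates even two non-aromatic rings that each carry one nitrogen, with an 8.0-fold lower number from compound 2 to compound 3 (0.90 log units; beyond the scatter) on going from piperidin-4-yl to pyrrolidin-3-yl. Pyrrolidin-3-yl still stands clear of 4-chlorophenyl on the same carbonyl carbon, with a 4.0-fold higher number from compound 1 to compound 3 (0.61 log units; beyond the scatter) here, so only part of the earlier rise remains. Nothing at hand accounts for the difference between the two rings. Open, as far as these compounds go, is how the mirror-image form of pyrrolidin-3-yl compares, and whether an open-chain amine or a carboxylic acid on this carbonyl carbon would match compound 2.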